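Thioether Purine Nucleosides and Nucleoside Transporter Binding

The source may report more compounds than this note shows. Statements on the series, on what has been measured and on what is new or still open speak of the compounds shown alone.

Measured compounds in an assay on isolated protein for binding affinity to Equilibrative nucleoside transporter 1 (Homo sapiens); a lower number here means a stronger inhibitor, a higher number a weaker inhibitor:
compound 1, `O=[N+]([O-])c1ccc2c(c1)CN(c1ncnc3c1nc1n3[C@@H]3O[C@H](CO1)[C@@H](O)[C@H]3O)CC2`, gives 331 nM;
compound 2, `Nc1nc(SCCc2ccccc2)c2ncn([C@@H]3O[C@H](CO)[C@@H](O)[C@H]3O)c2n1`, gives 16200 nM;
compound 3, `Cc1cc(C)c(SCc2ncnc3c2ncn3[C@@H]2O[C@H](CO)[C@@H](O)[C@H]2O)c(C)c1`, gives 33100 nM.

Compound 3 therefore carries the highest number of the measured set: its value stands beyond the scatter above that of compound 2 and far above that of compound 1. Compound 4, `OC[C@H]1O[C@@H](n2cnc3c(CSc4ccc(Br)cc4)ncnc32)[C@H](O)[C@@H]1O`, keeps the sulfur-linked side chain of compound 3 but carries a different aryl group: 4-bromophenyl in place of 2,4,6-trimethylphenyl on a sulfur. Among the measured compounds shown here, no measured pair isolates this change. In this assay the step from compound 3 is expected to be small, with the number able to move in either direction and no reason to expect a result near compound 1. The estimate means a step of a 1.5-fold lower number from compound 3 to compound 4 (0.18 log units; within the scatter), expected to lie within the scatter. Compound 4 is thus expected to give about 22000 nM, between 7000 nM and 70000 nM.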

Compound 4, half-maximal inhibitory concentration: 178 nM
Beside the measured number, compound 4's estimate is 120-fold (2.09 log units) above it; measured number outside the range, below it.
By their numbers in this assay, from the lowest: compounds 4 and 1 (each within the scatter of the next); then compound 2; then compound 3.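

In this assay, among the compounds shown here, the first comparison that changes one place shows that the aryl group on a sulfur strongly affects the read-out: 4-bromophenyl in place of 2,4,6-trimethylphenyl gives a 190-fold lower number from compound 3 to compound 4 (2.27 log units; beyond the scatter). The step is large even though both groups are a single six-membered aromatic ring of carbon only, with no hydrogen-bond donors or acceptors and no net charge. Going by these compounds, it remains open whether the bromine, the absence of the three methyl groups, or both account for the step, and how an unsubstituted phenyl, a 4-chlorophenyl or a 4-methoxyphenyl group would read at this sulfur. Nothing measured here gives a reason for the size of this step.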